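From methoxy to nitro on a shared core

The source may hold more compounds than are shown below. What is called first, only, known or untested is meant among the compounds shown, and "the series" means these compounds.

In a functional assay on MOLT-4 cells (Homo sapiens) for inhibition (a lower number here means a stronger inhibitor, a higher number a weaker inhibitor), compound 1 `O=C1CCCCC/C1=C\c1ccccc1` gives 215000 nM, compound 2 `O=C1CCCCC/C1=C\c1cccc(Br)c1` gives 176000 nM and compound 3 `COc1cccc(/C=C2\CCCCCC2=O)c1` gives 170000 nM. These three numbers lie within the usual scatter of one another, so compound 3 stands level with the other two and no order can be read among them.

The next structure, compound 4 `O=C1CCCCC/C1=C\c1cccc([N+](=O)[O-])c1`, carries nitro in place of methoxy on an aromatic carbon. The closest evidence comes from three measured exchanges on an aromatic carbon: bromo in place of hydrogen gave a 1.2-fold lower number from compound 1 to compound 2 (0.09 log units; within the scatter), methoxy in place of hydrogen gave a 1.3-fold lower number from compound 1 to compound 3 (0.10 log units; within the scatter), and methoxy in place of bromo gave a 1.0-fold lower number from compound 2 to compound 3 (0.02 log units; within the scatter). All three stay within the scatter. For the measured compounds named here, no nitro compound has been measured yet, so this evidence is indirect, and a step beyond the scatter is not expected in this assay. The estimated step is no change at the digits printed from compound 3 to compound 4 (within the scatter). The expected value for compound 4 is 170000 nM, with an estimated range from 85000 nM to 300000 nM.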

Compound 4, half-maximal inhibitory concentration: 39200 nM
Estimate against measurement, compound 4: 4.3-fold (0.64 log units) above; the whole stated range lies above it.
By their numbers in this assay, from the lowest: compound 4; then compounds 3, 2 and 1 (each within the scatter of the next).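

On this aromatic carbon, meta to a group of 9 heavy atoms, hydrogen, bromo and methoxy had given numbers level with one another in this assay, so the position could have seemed indifferent to what sits on it. Nitro ends that impression: it gives a 4.3-fold lower number from compound 3 to compound 4 (0.64 log units; beyond the scatter) and a 4.5-fold lower number from compound 2 to compound 4 (0.65 log units; beyond the scatter) and a 5.5-fold lower number from compound 1 to compound 4 (0.74 log units; beyond the scatter), so the position does respond to at least one group, though only modestly and with nitro alone going against the flat picture. Nothing available here accounts for why nitro stands apart from the other three groups.

The compounds shown leave open whether a nitrile, an amine or a carboxylic acid in this same place would follow nitro or stay level with hydrogen, bromo and methoxy.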